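The compounds below may be only part of what the source reports. "The series", "measured", "known", "first", "only" and "open" are said of these compounds alone.

Measured compounds in an assay on isolated protein with Bile acid receptor (Homo sapiens) as the target; a higher number here means that more compound is needed for the effect, a lower number that less compound is needed:

compound 1, `COC/C=C/c1cccc(N(Cc2ccc(/C=C/C(=O)OC(C)(C)C)cc2)C(=O)C2CCCCC2)c1`, gives 243 nM
compound 2, `CCOC/C=C/c1cccc(N(Cc2ccc(/C=C/C(=O)OC(C)(C)C)cc2)C(=O)C2CCCCC2)c1`, gives 220 nM
compound 3, `CC(C)(C)OC(=O)/C=C/c1cccc(N(Cc2ccc(CCC(=O)OC(C)(C)C)cc2)C(=O)C2CCCCC2)c1`, gives > 1000 nM

The value for compound 3 is a limit of the assay, not a number; compound 3 sits at the limit of > 1000 nM in this assay, at which 1 of the 3 values shown sits, the only one of the three to do so. Compounds 1 and 2, which both carry the 2-(tert-butoxycarbonyl)ethenyl group on the benzyl ring, give numbers well inside the range of the assay.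

Compound 4, `CC(C)(C)OC(=O)/C=C/c1ccc(CN(C(=O)C2CCCCC2)c2cccc(/C=C/C(=O)OC(C)(C)C)c2)cc1`, is not yet measured. It differs from compound 3 in one place: 2-(tert-butoxycarbonyl)ethenyl in place of 2-(tert-butoxycarbonyl)ethyl on an aromatic carbon. The change restores to the benzyl ring the unsaturated ester side chain that compounds 1 and 2 carry, while the anilide-side cinnamate ester of compound 3 is kept.

Only one measured step is shown, a 1.1-fold lower number from compound 1 to compound 2 (0.04 log units; within the scatter), and it concerns the alkoxy end of the other side chain, so it does not bear on the present change. What remains is the contrast between the numbers of compounds 1 and 2 and the limit of compound 3. On that basis the step from compound 3 to compound 4 is expected to give a lower number, an at least 5.0-fold lower number from compound 3 to compound 4 (0.69 log units; beyond the scatter). Compound 4 is therefore estimated at 200 nM, between 50 nM and 800 nM.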

Compound 4, half-maximal effective concentration: > 1000 nM
Compound 4 was reported as a limit; the forecaster's own chance of this, stated with the estimate: 15%; middle value at least 5.0-fold (0.69 log units) away from the limit.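

In this assay compound 4 gives > 1000 nM, a limit of the assay and not a number. Going by these compounds alone, compounds 3 and 4 therefore sit at the same limit, so no step between them can be read, and 2-(tert-butoxycarbonyl)ethenyl in place of 2-(tert-butoxycarbonyl)ethyl on this aromatic carbon does not by itself bring the series back to a number inside the range of the assay: the limit of > 1000 nM in this assay, at which 2 of the 4 values shown sit. The change at the other side chain can be read, and it places the loss there: with 2-(tert-butoxycarbonyl)ethenyl kept on the benzyl ring, tert-butoxycarbonyl in place of ethoxymethyl gives an at least 4.5-fold higher number from compound 2 to compound 4 (0.65 log units; beyond the scatter), and tert-butoxycarbonyl in place of methoxymethyl gives an at least 4.1-fold higher number from compound 1 to compound 4 (0.61 log units; beyond the scatter).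

Going by these compounds, how far compounds 3 and 4 lie past the limit remains unknown, so the saturated and unsaturated chains cannot be ranked when the other side chain ends in the tert-butyl ester. Also open, on these data alone, is whether a carboxylic acid in place of either tert-butyl ester, or an amine or a longer chain at the ether end, would give a number inside the range of this assay.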